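Amide to acid on the piperidine of a GIP receptor agonist

The source may report more compounds than this note shows. Statements on the series, on what has been measured and on what is new or still open speak of the compounds shown alone.

Measured compounds:
compound 1 `O=S1(=O)Cc2nc(-c3cc(F)c(Cl)cc3F)nc(N3CCC(CO)CC3)c2C1` gives 3.9 nM
compound 2 `NC(=O)CC1CCN(c2nc(-c3cc(F)c(Cl)cc3F)nc3c2CS(=O)(=O)C3)CC1` gives 8.3 nM
compound 3 `NC(=O)C1CCN(c2nc(-c3cc(F)c(Cl)cc3F)nc3c2CS(=O)(=O)C3)CC1` gives 21 nM

All three compounds were tested in a functional assay on HEK293 cells for agonist activity at Glucose-dependent insulinotropic receptor (Homo sapiens), read by reporter gene assay and cAMP accumulation, with a stated time of 6 h; a higher number here means that more compound is needed for the effect, a lower number that less compound is needed. Compound 3 stands highest of the three: the step of a 5.4-fold higher number from compound 1 to compound 3 (0.73 log units; beyond the scatter) and the step of a 2.5-fold higher number from compound 2 to compound 3 (0.40 log units; beyond the scatter) both lie beyond the scatter, so the carbamoyl on the saturated ring carbon is the least favourable of the three substituents seen so far.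

Compound 4 `O=C(O)C1CCN(c2nc(-c3cc(F)c(Cl)cc3F)nc3c2CS(=O)(=O)C3)CC1` keeps the core of compound 3 and changes the group at that same position: hydroxy in place of amino on a carbonyl carbon. For the measured compounds named here, no measured step changes an amide into an acid, so the prior steps bear on it only indirectly. They show that the number is sensitive to what sits on the piperidine carbon, with the step of a 5.4-fold higher number from compound 1 to compound 3 (0.73 log units; beyond the scatter) being the largest seen, and that a modest loss is the usual outcome when the hydroxymethyl of compound 1 is exchanged. On that basis compound 4 is expected to move by about a 1.9-fold higher number from compound 3 to compound 4 (0.28 log units; within the scatter), toward a higher number than compound 3, with wide uncertainty. For compound 4 in this assay the estimated value is 40 nM, with a range from 10 nM to 160 nM.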

Compound 4, effective concentration (reported as EC, without a stated level of effect): 560 nM
Beside the measured number, compound 4's estimate is 14-fold (1.15 log units) below it, and the stated range ends below it.
By their numbers in this assay, from the lowest: compound 1; then compound 2; then compound 3; then compound 4.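

In this assay, for the compounds shown here, the saturated ring carbon proves far less tolerant of this exchange than the earlier compounds suggested: hydroxy in place of amino on a carbonyl carbon gives a 27-fold higher number from compound 3 to compound 4 (1.43 log units; beyond the scatter) and so a large step, whereas every step among compound 1, compound 2 and compound 3 was modest. The exchange swaps one heavy atom for one and leaves the counts of hydrogen-bond donors and acceptors the same, so those counts do not separate the two groups, yet the carboxy group stands further still from the other two substituents, with a 67-fold higher number from compound 2 to compound 4 (1.83 log units; beyond the scatter) and with a 140-fold higher number from compound 1 to compound 4 (2.16 log units; beyond the scatter) placing compound 4 highest of the four. Nothing available here accounts for the size of this loss.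

Going by these compounds, what remains open is whether the loss also holds for a longer chain, since a carboxymethyl group would be the acid counterpart of the carbamoylmethyl group of compound 2. Also open, on these data alone, is whether a methyl ester or a tetrazole on the same ring carbon would stay close to compound 3 or follow compound 4.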